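A few compounds are considered here, and "the series" means these few. Any claim that something is new, unique, unknown or untested is made for them only; others in the source may bear on it.

Working notes on the series. Compound 1 `S=C(Nc1ccccc1)Nc1ccc2[nH]ccc2c1` is the unsubstituted parent. In an ADME assay on cells for inhibition of Amine oxidase [flavin-containing] A (Homo sapiens), read by spectrophotometry (a lower number here means a stronger inhibitor, a higher number a weaker inhibitor), compound 1 gives 57500 nM, the higher of the two numbers recorded so far. Compound 3 `S=C(Nc1ccc(Br)cc1)Nc1ccc2[nH]ccc2c1` gives 23000 nM in this assay; the step of a 2.5-fold lower number from compound 1 to compound 3 (0.40 log units; beyond the scatter) is modest but beyond the scatter. Compound 2 `Oc1ccc(NC(=S)Nc2ccc3[nH]ccc3c2)cc1` reaches only a limit of this assay, > 100000 nM. Accordingly an at least 1.7-fold higher number from compound 1 to compound 2 (0.24 log units; that floor lies within the scatter) has a floor that stays within the scatter, whereas an at least 4.3-fold lower number from compound 2 to compound 3 (0.63 log units; beyond the scatter). The unmeasured compound 4 `CC(=O)Nc1ccc(NC(=S)Nc2ccc3[nH]ccc3c2)cc1` differs from compound 1 by acetamido in place of hydrogen on an aromatic carbon. Both measured steps concern the same place on the ring: a bromo group there gave a modest gain, a hydroxy group gave no number at all. An acetamido group, like hydroxy, brings a hydrogen-bond donor to that place, so the step of a 1.6-fold higher number from compound 1 to compound 4 (0.19 log units; within the scatter) is expected to follow compound 2 rather than compound 3, small and toward a weaker inhibitor, with a real chance that only a limit is returned, as happened with the limit of > 100000 nM in this assay, at which 1 of the 3 values shown sits. Compound 4 is therefore estimated at 90000 nM, within 35000 nM to 230000 nM.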

Compound 4, half-maximal inhibitory concentration: 70000 nM
For compound 4 the middle estimate is 1.3-fold (0.11 log units) above the measured one; low and high end bracket the measured number.
By their numbers in this assay, from the lowest: compound 3; then compounds 1 and 4 (each within the scatter of the next). At a limit, above all of these: compound 2.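

Acetamido on this aromatic carbon, para to a large group, returns a real number in this assay, and a 1.2-fold higher number from compound 1 to compound 4 (0.09 log units; within the scatter) shows no change that can be separated from hydrogen. Against bromo at the same place the picture differs, with a 3.0-fold higher number from compound 3 to compound 4 (0.48 log units; beyond the scatter), so among the groups shown only bromo lowers the number beyond the scatter relative to hydrogen. Compound 2 stands at a limit of the assay, so with an at least 1.4-fold lower number from compound 2 to compound 4 (0.15 log units; that floor lies within the scatter) the acetamido and hydroxy groups are not separated, and a limit remains in the series: the limit of > 100000 nM in this assay, at which 1 of the 4 values shown sits.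

Open, going by these compounds, is whether a chloro or iodo group at this place would match bromo, and whether an amine or a carboxylic acid there would give a number or a limit. Also open, on these data alone, is whether a change elsewhere on the shared core would move the number at all.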